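Removing a Ring Fluorine Across Two Cores in Caco-2

The source may report more compounds than this note shows. Statements on the series, on what has been measured and on what is new or still open speak of the compounds shown alone.

Measured so far:
Compound 1, `O=C(NCc1cc(Cl)ccc1-n1cnnn1)[C@@H]1CC=NN1C(=O)[C@H](O)c1ccccc1F`: 8.9 10^-6 cm/s
Compound 2, `O=C(NCc1cc(Cl)ccc1-n1cnnn1)[C@@H]1CC=NN1C(=O)[C@H](O)c1ccccc1`: 7 10^-6 cm/s
Compound 3, `O=C(NCc1cc(Cl)ccc1-n1cnnn1)[C@@H]1C[C@@H]2C[C@@H]2N1C(=O)[C@H](O)c1ccccc1F`: 16 10^-6 cm/s

Compound 1 and compound 2 share one core and differ in a single place: hydrogen in place of fluoro on an aromatic carbon. In an ADME assay on Caco-2 cells (Homo sapiens) for permeability, read by LC-MS, in the apical to basolateral direction, with a stated time of 60 min, at pH 6.5 (on this read-out higher numbers stand for higher permeability and lower numbers for lower permeability), this change gave a 1.3-fold lower number from compound 1 to compound 2 (0.10 log units; within the scatter), so the two numbers cannot be told apart with confidence. Compound 3 carries a second core; the difference between the two cores is not broken down here. Its number is the highest of the three, though its gap to compound 1 lies within the scatter and only its gap to compound 2 lies beyond it.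

Compound 4, `O=C(NCc1cc(Cl)ccc1-n1cnnn1)[C@@H]1C[C@@H]2C[C@@H]2N1C(=O)[C@H](O)c1ccccc1`, has not yet been measured in this assay. Among the compounds with values here, it differs from compound 3 by hydrogen in place of fluoro on an aromatic carbon, the same change as the one from compound 1 to compound 2, in the same place. The step from compound 3 to compound 4 is therefore expected to be small, roughly a 1.3-fold lower number from compound 3 to compound 4 (0.12 log units; within the scatter), because the earlier step of this kind was a 1.3-fold lower number from compound 1 to compound 2 (0.10 log units; within the scatter). On that basis compound 4 is estimated at 12 10^-6 cm/s, most likely between 7 10^-6 cm/s and 20 10^-6 cm/s.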

Compound 4, apparent permeability: 8 10^-6 cm/s
Estimate against measurement, compound 4: 1.5-fold (0.18 log units) above; low and high end bracket the measured number.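

In this assay, putting hydrogen in place of the fluoro on the aromatic ring gave a 2.0-fold lower number from compound 3 to compound 4 (0.30 log units; within the scatter), so on this second core the step again stays within the usual spread of repeated measurements. Set side by side, the two steps cannot be told apart: the same change on two cores in this assay, a 1.3-fold lower number (0.10 log units; within the scatter) from compound 1 to compound 2 and a 2.0-fold lower number (0.30 log units; within the scatter) from compound 3 to compound 4, 1.6-fold (0.20 log units) apart, within the scatter of two such steps. In these two pairs the change carries from the core of compound 1 to the core of compound 3 with no detectable difference in size, but this does not show that the change has a real effect on either core, and two pairs cannot establish a rule for the whole series.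

The compounds shown compare only fluoro and hydrogen at this place on the ring. They leave open whether a larger or different group there, such as a methoxy group, an amine or a carboxylic acid, would give a step beyond the scatter, and whether that step would match on both cores.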